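Carbamate for amide on the low end of the series

This account rests on a few compounds, and the source may have more. Where it says the series, first, only, none or still open, it means among the compounds named here.

In a functional assay on WI-38 VA13 cells (Homo sapiens) for cytotoxicity (a lower number here means that less compound is needed, a higher number that more compound is needed for the effect), compound 3 (`CCCC(=O)Nc1nc2ccc(NC(=O)c3c(Cl)cccc3Cl)cc2s1`) gives 0.01 ug/mL, the lowest of three numbers. Compound 2 (`CCCC(C)C(=O)Nc1ccc2nc(NC(=O)C3CCCCC3)sc2c1`) gives 0.14 ug/mL and compound 1 (`N#Cc1cccc(C(=O)Nc2ccc3nc(NC(=O)C4CCCCC4)sc3c2)c1`) gives 0.52 ug/mL. Compound 4 (`CC(C)OC(=O)Nc1nc2ccc(NC(=O)c3c(Cl)cccc3Cl)cc2s1`) carries isopropoxy in place of propyl on a carbonyl carbon of compound 3: isopropoxy in place of propyl on a carbonyl carbon. Among the measured compounds shown here, no measured step covers this exchange. For the measured compounds named here, the one available step, a 3.7-fold lower number from compound 1 to compound 2 (0.57 log units; beyond the scatter), is modest and concerns a different group, so it offers only a rough guide to size. With compound 3 at the bottom of the range at 0.01 ug/mL, a modest move to a higher number is expected, and the estimated step is a 2.0-fold higher number from compound 3 to compound 4 (0.30 log units; within the scatter). The estimate for compound 4 is 0.02 ug/mL, with an expected range of 0.005 ug/mL to 0.1 ug/mL.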

Compound 4, half-maximal effective concentration: 0.0026 ug/mL
Beside the measured number, compound 4's estimate is 7.7-fold (0.89 log units) above it, outside the stated range (below it).
By their numbers in this assay, from the lowest: compound 4; then compound 3; then compound 2; then compound 1.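

At the carbonyl carbon on the amide-type nitrogen, isopropoxy in place of propyl gives a 3.8-fold lower number from compound 3 to compound 4 (0.59 log units; beyond the scatter) in this assay. The number therefore moves lower still from the low end of the series, showing that this position accepts the carbamate. The data offer no measured explanation for this step.

Open, going by these compounds, is whether the oxygen or the branching carries the step. A straight propoxy and an isopropyl on this carbonyl carbon would separate the two.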